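A few compounds are considered here, and "the series" means these few. Any claim that something is new, unique, unknown or untested is made for them only; others in the source may bear on it.

Compound 1, with the structure `CC(=O)Oc1ccccc1C(=O)O[C@H]1CO[C@H]2[C@@H]1OC[C@H]2OC(=O)c1ccccc1C`, is the shared core carrying an acetoxybenzoyl ester on one side and a (2-methylphenyl)carbonyl ester on the other. Going by the values given here, in an ADME assay on a cell-free system (plasma, Homo sapiens) for metabolic stability, with Plasma (Rattus norvegicus) as the target, read by HPLC, at pH 7.4 (a lower number here means that the compound disappears faster, a higher number that the compound lasts longer), compound 1 gives 0.0138 h, the lowest of the three numbers measured so far. Compound 2, `CC(=O)Oc1ccccc1C(=O)O[C@H]1CO[C@H]2[C@@H]1OC[C@H]2OC(=O)c1ccccc1OC(=O)c1ccccc1`, gives 0.0722 h, and compound 3, `CCOc1cc(OCC)cc(C(=O)O[C@@H]2CO[C@H]3[C@@H]2OC[C@@H]3OC(=O)c2ccccc2OC(C)=O)c1`, gives 0.0283 h. Both measured steps start from compound 1 and both touch the second ester: a 5.2-fold higher number from compound 1 to compound 2 (0.72 log units; beyond the scatter), and a 2.1-fold higher number from compound 1 to compound 3 (0.31 log units; beyond the scatter).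

Compound 4, `CC(=O)Oc1ccccc1C(=O)O[C@H]1CO[C@H]2[C@@H]1OC[C@H]2O[N+](=O)[O-]`, is not yet measured. It differs from compound 1 in that same place: nitro in place of (2-methylphenyl)carbonyl on an oxygen on a saturated carbon. The (2-methylphenyl)carbonyl leaves altogether and a nitro group takes its place on the oxygen, so the change is of a different kind from the two measured steps, which only reshaped the aryl part of that ester. Neither step therefore bears directly on it; what they do show is that every alteration made so far at this oxygen has moved the number upward from compound 1. On that basis a modest rise is expected rather than a fall, stated with caution as a 1.8-fold higher number from compound 1 to compound 4 (0.26 log units; within the scatter). Compound 4 is thus estimated at 0.025 h, within a range from 0.01 h to 0.08 h.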

Compound 4, half-life: 0.00314 h
Compound 4: the middle estimate sits 8.0-fold (0.90 log units) above what was measured; the measured number lies below the stated range.
By their numbers in this assay, from the lowest: compound 4; then compound 1; then compound 3; then compound 2.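

Changing what sits on this oxygen does not always raise the number: in this assay nitro in place of (2-methylphenyl)carbonyl gives a 4.4-fold lower number from compound 1 to compound 4 (0.64 log units; beyond the scatter), so the rise seen for compound 2 and compound 3 is no general pattern at this position, and compound 4 goes against it. Going by these compounds alone, the two earlier steps kept a carbonyl on this oxygen and reshaped only the aryl part, whereas this change removes the carbonyl and its aromatic ring together, and it is the only one of the three steps to lower the number. This single step shows the direction and size of the change but not its origin, and nothing available explains it.

From the compounds shown here alone, whether the lower number goes with the entry of nitro or with the departure of the (2-methylphenyl)carbonyl remains open, and a free hydroxyl or a butanoyl ester on this oxygen would help to separate the two. Also open, going by these compounds, is how the number would respond to an amine or a carboxylic acid on the aryl part of the ester, and whether any of these steps would carry over to a different group on the other side of the shared core.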